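The source may hold more compounds than are shown below. What is called first, only, known or untested is meant among the compounds shown, and "the series" means these compounds.

Measured in an assay on isolated protein for displacement of a labelled ligand from Gonadotropin-releasing hormone receptor (Rattus norvegicus); on this read-out lower numbers stand for stronger inhibition and higher numbers for weaker inhibition: compound 1 `Cc1nc(CN2CCN(c3cccc4[nH]c(-c5ccc(C(C)(C)C)cc5)nc34)CC2)c[nH]1` gives 28 nM; compound 2 `CCc1nc(C)c(CN2CCN(c3cccc4[nH]c(-c5ccc(C(C)(C)C)cc5)nc34)CC2)o1` gives 320 nM; compound 3 `CCc1cc(CN2CCN(c3cccc4[nH]c(-c5ccc(C(C)(C)C)cc5)nc34)CC2)nn1C` gives 350 nM.

Compound 2 stands second highest of the three numbers in this assay ; its nearest neighbour is compound 3 with a 1.1-fold higher number from compound 2 to compound 3 (0.04 log units; within the scatter), and its furthest is compound 1 with an 11-fold higher number from compound 1 to compound 2 (1.06 log units; beyond the scatter). Compound 4 `CCCn1cnc(CN2CCN(c3cccc4[nH]c(-c5ccc(C(C)(C)C)cc5)nc34)CC2)c1C` has not been measured. The change from compound 2 reads (5-methyl-1-propyl-1H-imidazol-4-yl in place of 2-ethyl-4-methyl-1,3-oxazol-5-yl on a saturated chain carbon bound to an amine nitrogen in a ring). Within the data shown here, the steps that bear on it are the change of the five-membered ring from compound 1, seen in an 11-fold higher number from compound 1 to compound 2 (1.06 log units; beyond the scatter) and a 13-fold higher number from compound 1 to compound 3 (1.10 log units; beyond the scatter), and the swap between two rings lacking a donor in a 1.1-fold higher number from compound 2 to compound 3 (0.04 log units; within the scatter). Since compound 4 also carries no donor, only a small step is expected, a 1.6-fold lower number from compound 2 to compound 4 (0.20 log units; within the scatter). Compound 4 is estimated at 200 nM, within 60 nM to 700 nM.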

Compound 4, half-maximal inhibitory concentration: 47 nM
Beside the measured number, compound 4's estimate is 4.3-fold (0.63 log units) above it, outside the stated range (below it).
By their numbers in this assay, from the lowest: compounds 1 and 4 (each within the scatter of the next); then compounds 2 and 3 (each within the scatter of the next).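

At this position, a hydrogen-bond donor on the ring is not needed for a low number in this assay: 5-methyl-1-propyl-1H-imidazol-4-yl has none, yet it gives a 6.8-fold lower number from compound 2 to compound 4 (0.83 log units; beyond the scatter) and a 7.4-fold lower number from compound 3 to compound 4 (0.87 log units; beyond the scatter), while a 1.7-fold higher number from compound 1 to compound 4 (0.22 log units; within the scatter) stays within the scatter. Among these compounds, the two imidazolyl groups thus stand apart from the oxazolyl and pyrazolyl groups. No measurement shown explains this difference.

As far as these compounds go, whether the imidazole ring or its methyl and propyl groups set the number stays open. So does the outcome with a butyl chain in place of the propyl.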